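Moving the Ring Nitrogen in an Amide Series

The compounds below may be only part of what the source reports. "The series", "measured", "known", "first", "only" and "open" are said of these compounds alone.

Measured compounds:
Compound 1 `Cc1ccc(F)cc1N(C)C(=O)c1ccc(-c2ccc(O)cc2)o1` gives 41 nM in an assay on cytosol from placenta for inhibition of 17-beta-hydroxysteroid dehydrogenase type 1 (Homo sapiens), read by HPLC, with a stated time of 10 min, in the presence of a further agent that is not named here; a lower number here means a stronger inhibitor, a higher number a weaker inhibitor.
Compound 2 `Cc1cc(F)ccc1N(C)C(=O)c1ccc(-c2ccc(O)cc2)o1` gives 23 nM in this assay.
Compound 3 `Cc1cccnc1N(C)C(=O)c1ccc(-c2ccc(O)cc2)o1` gives 3300 nM in this assay.

Compound 3 has the highest number of the three. The difference between compound 1 and compound 2 is a 1.8-fold lower number from compound 1 to compound 2 (0.25 log units; within the scatter), whereas replacing the fluoromethylphenyl group by a pyridinyl group gives an 80-fold higher number from compound 1 to compound 3 (1.91 log units; beyond the scatter) and a 140-fold higher number from compound 2 to compound 3 (2.16 log units; beyond the scatter), both large.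

Compound 4 `Cc1ncccc1N(C)C(=O)c1ccc(-c2ccc(O)cc2)o1` keeps every atom of compound 3 and differs only in the change (2-methylpyridin-3-yl in place of 3-methylpyridin-2-yl on an amide-type nitrogen). For the measured compounds named here, no measured step compares two pyridinyl groups with each other, so none of the three steps bears directly on this change. The two large steps into compound 3 show only how far a pyridinyl group sits from the fluoromethylphenyl groups; they do not tell whether shifting the ring nitrogen and the methyl group recovers part of that loss or leaves it unchanged. The expectation for compound 4 is therefore centred a little below compound 3 in number, but with wide uncertainty in both directions.

Compound 4 is estimated at 1500 nM in this assay, with a range from 300 nM to 8000 nM, which corresponds to an expected step of a 2.2-fold lower number from compound 3 to compound 4 (0.34 log units; beyond the scatter).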

Compound 4, half-maximal inhibitory concentration: 160 nM
Estimate against measurement, compound 4: 9.4-fold (0.97 log units) above; the measured number lies below the stated range.
By their numbers in this assay, from the lowest: compounds 2 and 1 (each within the scatter of the next); then compound 4; then compound 3.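

In this assay, the step to 2-methylpyridin-3-yl in place of 3-methylpyridin-2-yl on the amide-type nitrogen gives a 21-fold lower number from compound 3 to compound 4 (1.31 log units; beyond the scatter), although the group that leaves and the group that enters have the same heavy atoms, the same single aromatic ring and the same hydrogen-bond counts, so at this position the arrangement of those atoms alone changes the result substantially. The large distance from the fluoromethylphenyl groups is therefore not shared by both pyridinyl groups: the step from the 5-fluoro-2-methylphenyl group gives a 3.9-fold higher number from compound 1 to compound 4 (0.59 log units; beyond the scatter), and the step from the 4-fluoro-2-methylphenyl group gives a 7.0-fold higher number from compound 2 to compound 4 (0.84 log units; beyond the scatter), both modest but still beyond the scatter. Nothing available here accounts for the difference between the two pyridinyl groups.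

The compounds shown leave open whether a fluorine on the 2-methylpyridin-3-yl ring would close the remaining gap to compound 1 and compound 2. They also do not show how that ring would fare with a methoxy group or a chlorine in place of its methyl group, or how a pyrimidine ring would compare at the same amide-type nitrogen.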